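Extending the aryloxy ring of a pyrrolidine acid series

The source may hold more compounds than are shown below. What is called first, only, known or untested is meant among the compounds shown, and "the series" means these compounds.

Measured compounds:
compound 1, `COc1ccc(Oc2ccc(N3C[C@@H](C(F)(F)F)C[C@H]3CC(=O)O)cc2)c(C)c1`, 39 nM
compound 2, `Cc1cccc(Oc2ccc(N3C[C@@H](C(F)(F)F)C[C@H]3CC(=O)O)cc2)c1C`, 60 nM

In an assay on HEK293 cells for binding affinity to Free fatty acid receptor 1 (Homo sapiens), read by scintillation counting and radioligand binding, with a stated time of 1 h (on this read-out lower numbers stand for stronger inhibition and higher numbers for weaker inhibition), compound 1 gives 39 nM and compound 2 gives 60 nM. Within the data shown here, the only step between them, a 1.5-fold higher number from compound 1 to compound 2 (0.19 log units; within the scatter), lies within the scatter, so compound 2 and compound 1 cannot be separated on these numbers; compound 2 stands at one end of a pair whose two members are indistinguishable.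

Compound 3, `COc1ccc(F)c(Cc2cccc(Oc3ccc(N4C[C@@H](C(F)(F)F)C[C@H]4CC(=O)O)cc3)c2C)c1`, is not yet measured. It differs from compound 2 by 2-fluoro-5-methoxyphenyl in place of hydrogen on a saturated chain carbon bound to an aromatic carbon. Among the measured compounds shown here, the one measured step, from compound 1 to compound 2, concerns a swap of substituents on the ring attached to the oxygen and says nothing about adding a second aromatic ring on a chain carbon. For the measured compounds named here, no step therefore bears on this change, and its direction is unknown.

With no guidance from the data, compound 3 is expected to remain close to compound 2, with a step of about a 1.1-fold lower number from compound 2 to compound 3 (0.04 log units; within the scatter) in this assay. The estimate for compound 3 is 55 nM, with a range from 12 nM to 250 nM.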

Compound 3, inhibition constant: 49 nM
Estimate against measurement, compound 3: 1.1-fold (0.05 log units) above; the measured number falls inside the stated range.
By their numbers in this assay, from the lowest: compounds 1, 3 and 2 (each within the scatter of the next).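

In this assay, turning the methyl of compound 2 into 2-fluoro-5-methoxybenzyl gives a 1.2-fold lower number from compound 2 to compound 3 (0.09 log units; within the scatter), so compound 3 cannot be separated from compound 2 on these numbers. The earlier pair differed only in the substituents on the ring bound through the oxygen, whereas this step shows that a saturated chain carbon bound to an aromatic carbon can carry a 2-fluoro-5-methoxyphenyl, a group of 9 heavy atoms with one six-membered aromatic ring, and the read-out stays within the scatter. Nothing shown here gives a reason for this result.

From the compounds shown here alone, it remains open whether the number would hold with a plain benzyl, or with an amine or a carboxylic acid on the added ring in place of the fluorine and the methoxy. Going by these compounds, it is also open whether 2-fluoro-5-methoxybenzyl would give a similar result on the ring carrying the methoxy and methyl groups of compound 1, as this single step covers only the ring of compound 2.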